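Chain Lengthening in a Series of Weak Inhibitors

The compounds below may be only part of what the source reports. "The series", "measured", "known", "first", "only" and "open" are said of these compounds alone.

Compound 1 `CCCCCCOc1cc(OC)ccc1C(C)=O`, compound 2 `CCCCCCCCOc1cc(OC)ccc1C(C)=O` and compound 3 `CCCCCCCCCCCCCCOc1cc(OC)ccc1C(C)=O` share one core and differ only in the length of a saturated chain attached through an oxygen on an aromatic ring. In a functional assay, read by spectrophotometry, with a stated time of 6 min (a higher number here means a weaker inhibitor, a lower number a stronger inhibitor), compound 1 gives 42100000 nM, compound 2 gives 38300000 nM and compound 3 gives 38000000 nM. The change ethyl in place of hydrogen on a saturated chain carbon, six bonds along the chain from an oxygen on an aromatic ring brings a 1.1-fold lower number from compound 1 to compound 2 (0.04 log units; within the scatter). The larger change octyl in place of hydrogen on a saturated chain carbon, six bonds along the chain from an oxygen on an aromatic ring brings a 1.1-fold lower number from compound 1 to compound 3 (0.04 log units; within the scatter), and a 1.0-fold lower number from compound 2 to compound 3 (0.00 log units; within the scatter) is likewise seen. Compound 4 `CCCCCCCCCCCCCCCCOc1cc(OC)ccc1C(C)=O` carries ethyl in place of hydrogen on a saturated chain carbon, ten or more bonds along the chain from an oxygen on an aromatic ring, the same kind of change as from compound 1 to compound 2, though at a different place on the chain. Because a 1.1-fold lower number from compound 1 to compound 2 (0.04 log units; within the scatter) and a 1.0-fold lower number from compound 2 to compound 3 (0.00 log units; within the scatter) both stay within the scatter, the step of a 1.0-fold lower number from compound 3 to compound 4 (0.01 log units; within the scatter) is expected to stay within the scatter as well. Compound 4 is estimated at 37000000 nM in this assay, with a range from 20000000 nM to 70000000 nM.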

Compound 4, half-maximal inhibitory concentration: 36300000 nM
Compound 4: middle estimate off by 1.0-fold (0.01 log units), on the high side, and the stated range covers the measured number.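

In this assay, the ethyl change on the longer chain gives a 1.0-fold lower number from compound 3 to compound 4 (0.02 log units; within the scatter), and the octyl change gives a 1.1-fold lower number from compound 2 to compound 4 (0.02 log units; within the scatter). The ethyl change reads alike on the shorter and longer chains: the same change on two cores in this assay, a 1.1-fold lower number (0.04 log units; within the scatter) from compound 1 to compound 2 and a 1.0-fold lower number (0.02 log units; within the scatter) from compound 3 to compound 4, 1.1-fold (0.02 log units) apart, within the scatter of two such steps. The octyl change agrees as well, but every one of these steps lies within the scatter, so the agreement shows only that no measurable effect appears on either core, not that a change with a real effect would carry from one core to another: the same change on two cores in this assay, a 1.1-fold lower number (0.04 log units; within the scatter) from compound 1 to compound 3 and a 1.1-fold lower number (0.02 log units; within the scatter) from compound 2 to compound 4, 1.1-fold (0.02 log units) apart, within the scatter of two such steps.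

The compounds shown leave open how a chain ending in an amine or a carboxylic acid would read in this assay. As far as these compounds go, a much shorter chain, such as methyl, also remains open.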